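The compounds below may be only part of what the source reports. "The series", "measured", "known", "first", "only" and "open" are said of these compounds alone.

Compound 2 `C/C=C/C=C/C(=O)N[C@H](C(=O)NCCCCCCCCCCCC)[C@@H](C)O` carries a (penta-1,3-dien-1-yl)carbonyl group on an amine nitrogen. In a functional assay on HepG2 cells (Homo sapiens) for cytotoxicity, read by MTT assay, with a stated time of 48 h (a lower number here means a stronger inhibitor, a higher number a weaker inhibitor), compound 2 gives > 400000 nM, which is a limit of the assay rather than a number (the limit of > 400000 nM in this assay, at which 1 of the 2 values shown sits). Compound 1 `CCCCCCCCCCCCNC(=O)[C@@H](NC(=O)c1cccs1)[C@@H](C)O`, which has a thiophen-2-yl carbonyl in that position, gives 30100 nM. Going by the values given here, the only measured step, an at least 13-fold higher number from compound 1 to compound 2 (1.12 log units; beyond the scatter), is therefore large. Compound 3 `CCCCCCCCCCCCNC(=O)[C@@H](NS(=O)(=O)c1cccs1)[C@@H](C)O` differs from compound 2 by (thiophen-2-yl)sulfonyl in place of (penta-1,3-dien-1-yl)carbonyl on an amine nitrogen, bringing the thiophene ring back, now attached through a sulfonyl. Because compound 1 stands at 30100 nM, a downward step in this assay is expected, roughly an at least 6.6-fold lower number from compound 2 to compound 3 (0.82 log units; beyond the scatter). Compound 3 is estimated at 60000 nM, within 15000 nM to 400000 nM.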

Compound 3, half-maximal inhibitory concentration: 25900 nM
Compound 3: middle estimate off by 2.3-fold (0.36 log units), on the high side, and the stated range covers the measured number.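

Replacing (thiophen-2-yl)carbonyl with (thiophen-2-yl)sulfonyl on the amine nitrogen gives a 1.2-fold lower number from compound 1 to compound 3 (0.07 log units; within the scatter), so in this assay the carbonyl and sulfonyl links cannot be told apart when thiophene is present. The change from the diene group gives an at least 15-fold lower number from compound 2 to compound 3 (1.18 log units; beyond the scatter), so the sulfonyl compound, like compound 1, stands clearly apart from compound 2. The value for compound 2 is a limit of the assay, not a number: the limit of > 400000 nM in this assay, at which 1 of the 3 values shown sits.

Going by these compounds, it remains open whether a phenyl ring on the sulfonyl would match thiophene. A penta-1,3-dien-1-yl group on a sulfonyl is also untested among these compounds.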